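Pyridyl amide isomer in the kallikrein-7 series

The source may hold more compounds than are shown below. What is called first, only, known or untested is meant among the compounds shown, and "the series" means these compounds.

Compound 1 `COc1ccc(Cl)cc1C[C@@H]1CN/C(=N\N(C)C)CN(CC(=O)Nc2ccccn2)C1=O` is the weaker of the two measured compounds in an assay on isolated protein for inhibition of kallikrein-7 (Homo sapiens), read by fluorescence, with stated times of 10 min and 30 min (on this read-out higher numbers stand for weaker inhibition and lower numbers for stronger inhibition), where compound 1 gives 16000 nM; compound 2 `CO/N=C1/CN(CC(=O)Nc2cccc(C(=O)O)c2)C(=O)[C@H](Cc2cc(Cl)ccc2OC)CN1` in this assay gives 14000 nM, and the two values lie within the usual scatter, so no order between them can be read. Compound 3 `COc1ccc(Cl)cc1C[C@@H]1CN/C(=N\N(C)C)CN(CC(=O)Nc2cccnc2)C1=O` differs from compound 1 by pyridin-3-yl in place of pyridin-2-yl on an amide-type nitrogen. For the measured compounds named here, no measured pair shows this change here, so the step is expected to stay within the scatter, with no clear direction, giving an expected step of no change at the digits printed from compound 1 to compound 3 (within the scatter). Compound 3 is therefore estimated at 16000 nM in this assay, with a range from 5000 nM to 50000 nM.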

Compound 3, half-maximal inhibitory concentration: 9000 nM
Compound 3: the middle estimate sits 1.8-fold (0.25 log units) above what was measured; the measured number falls inside the stated range.
By their numbers in this assay, from the lowest: compounds 3, 2 and 1 (each within the scatter of the next).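

In this assay, for the compounds shown here, pyridin-3-yl in place of pyridin-2-yl on the amide-type nitrogen gives a 1.8-fold lower number from compound 1 to compound 3 (0.25 log units; within the scatter), the first one-place comparison. With the same atoms joined differently, this isomer change does not separate compound 1 from compound 3, so no preference between the two pyridyl groups can be read. No measured property bears on this result.

As far as these compounds go, whether pyridin-4-yl or an aminopyridinyl group on this nitrogen would move the number beyond the scatter remains open.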